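This account rests on a few compounds, and the source may have more. Where it says the series, first, only, none or still open, it means among the compounds named here.

Working notes on the series. Compound 1 `Cc1ccc2occ([C@@H]3[C@H]4C(=O)N(c5ccccc5)C(=O)[C@H]4ON3c3ccccc3)c(=O)c2c1` returns only a limit of the assay, > 60000 nM, in a functional assay on THP-1 cells (Homo sapiens) for inhibition, read by sulforhodamine B assay, with a stated time of 48 h; a higher number here means a weaker inhibitor, a lower number a stronger inhibitor. That limit is described as the limit of > 60000 nM in this assay, at which 1 of the 2 values shown sits. Within the data shown here, compound 2 `N#C[C@H]1C[C@@H](c2coc3ccc(Cl)cc3c2=O)N(c2ccccc2)O1` in this assay gives 35000 nM, the single measured number in this set, so nothing places it relative to another number. Compound 3 `COC(=O)[C@H]1C[C@@H](c2coc3ccc(Cl)cc3c2=O)N(c2ccccc2)O1` differs from compound 2 by methoxycarbonyl in place of cyano on a saturated ring carbon. Among the measured compounds shown here, no measured step covers this change, and the change is expected to produce a 1.1-fold higher number from compound 2 to compound 3 (0.06 log units; within the scatter), nothing beyond the usual scatter. Compound 3 is therefore estimated at 40000 nM, with a range from 15000 nM to 100000 nM.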

Compound 3, half-maximal inhibitory concentration: > 60000 nM
Compound 3 ended at the assay's limit; the forecaster's own chance of this, stated with the estimate: 35%; middle value at least 1.5-fold (0.17 log units) away from the limit.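

Among these compounds, on the saturated ring carbon next to the ring oxygen, methoxycarbonyl in place of cyano gives an at least 1.7-fold higher number from compound 2 to compound 3 (0.23 log units; that floor lies within the scatter), the first measured step at this position. That size is only a floor, so the change is not shown to go beyond the usual scatter, though the true step may be larger. Compound 2 remains the only compound with a measured number in this assay, and the rest of the comparison rests on a limit: the limit of > 60000 nM in this assay, at which 2 of the 3 values shown sit.

Going by these compounds, how far compound 3 actually lies from compound 2 stays open. So does whether a carboxylic acid or an aminomethyl group on this ring carbon would give a measured number.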